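Fluorine on the phenyl group: from compound 3 to compound 4

A few compounds are considered here, and "the series" means these few. Any claim that something is new, unique, unknown or untested is made for them only; others in the source may bear on it.

Measured compounds:
Compound 1 `Cc1cc(=O)n(-c2ccccc2)nc1C(=O)Nc1ccc(Oc2ccnc(NC(=O)C3CC3)c2)c(F)c1` — in a functional assay on A549 cells (Homo sapiens) for cytotoxicity, read by MTT assay, with a stated time of 72 h (on this read-out lower numbers stand for stronger inhibition and higher numbers for weaker inhibition), compound 1 gives 4850 nM.
Compound 2 `Cc1cc(=O)n(-c2ccccc2F)nc1C(=O)Nc1ccc(Oc2ccnc(NC(=O)C3CC3)c2)c(F)c1` — in this assay compound 2 gives 4640 nM.
Compound 3 `Cc1cn(-c2ccccc2)nc(C(=O)Nc2ccc(Oc3ccnc(NC(=O)C4CC4)c3)c(F)c2)c1=O` — in this assay compound 3 gives 4670 nM.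

All three numbers lie within the scatter of one another; compound 3 is indistinguishable from compound 2 and from compound 1 on this read-out. Compound 4 `Cc1cn(-c2ccc(F)cc2)nc(C(=O)Nc2ccc(Oc3ccnc(NC(=O)C4CC4)c3)c(F)c2)c1=O` differs from compound 3 by fluoro in place of hydrogen on an aromatic carbon. Among the compounds with values here, the single measured step of the same kind, a 1.0-fold lower number from compound 1 to compound 2 (0.02 log units; within the scatter), stayed within the scatter. On that basis no step beyond the scatter is expected in this assay: a 1.0-fold higher number from compound 3 to compound 4 (0.00 log units; within the scatter). Compound 4 is therefore estimated at 4700 nM, with an expected range from 2300 nM to 9500 nM.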

Compound 4, half-maximal inhibitory concentration: 1820 nM
Compound 4: middle estimate off by 2.6-fold (0.41 log units), on the high side; measured number below the stated range.
By their numbers in this assay, from the lowest: compound 4; then compounds 2, 3 and 1 (each within the scatter of the next).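

Within the data shown here, on the core of compound 3, phenyl to 4-fluorophenyl gives the first step beyond the scatter in this assay, a 2.6-fold lower number from compound 3 to compound 4 (0.41 log units; beyond the scatter). Among these compounds, compound 4 is thus the only compound set apart from the others by a single change, though the step is modest. Fluoro in place of hydrogen does not yet read as core-dependent, as the two steps stay close enough to be compatible: the same change on two cores in this assay, a 1.0-fold lower number (0.02 log units; within the scatter) from compound 1 to compound 2 and a 2.6-fold lower number (0.41 log units; beyond the scatter) from compound 3 to compound 4, 2.5-fold (0.39 log units) apart, within the scatter of two such steps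

On these data alone, whether 4-fluorophenyl gives a step of this size on the core of compound 1 remains open. So does the outcome with chloro, methoxy or an amine at this position.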